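The source may report more compounds than this note shows. Statements on the series, on what has been measured and on what is new or still open speak of the compounds shown alone.

In a functional assay on RPMI-8226 cells (Homo sapiens) for inhibition, read by sulforhodamine B assay, with a stated time of 48 h, tested at 10 uM (a higher number here means a weaker effect of the compound at the concentration tested, a lower number a stronger effect), compound 1 `O=C(Nc1cccc(-n2cc(-c3ccncc3)c(-c3cc(O)cc(Cl)c3)n2)c1)Nc1ccc(Cl)c(Cl)c1` gives -15.3%. Compound 2 `COc1cc(Cl)cc(-c2nn(-c3cccc(NC(=O)Nc4ccc(Cl)c(Cl)c4)c3)cc2-c2ccncc2)c1` carries methyl in place of hydrogen on an oxygen on an aromatic ring and in this assay compound 2 gives -4.44%, so that a number 10.9 percentage points higher from compound 1 to compound 2 (beyond the scatter). Compound 3 `O=C(Nc1cccc(-n2cc(-c3ccncc3)c(-c3cc(O)cc(Cl)c3)n2)c1)c1cc(C(F)(F)F)cc(C(F)(F)F)c1` gives 32.1% in this assay, the highest of the three numbers; the difference between the core of compound 3 and the core of compound 1 is not broken down here. Compound 4 `COc1cc(Cl)cc(-c2nn(-c3cccc(NC(=O)c4cc(C(F)(F)F)cc(C(F)(F)F)c4)c3)cc2-c2ccncc2)c1` has not yet been measured. It carries methyl in place of hydrogen on an oxygen on an aromatic ring, the same change at the same place as the one seen in the measured pair. Because the earlier step was a number 10.9 percentage points higher from compound 1 to compound 2 (beyond the scatter), a step of similar size is expected in this assay, a number 9.9 percentage points higher from compound 3 to compound 4 (within the scatter), though this expectation rests on a single pair. Compound 4 is therefore estimated at 42%, within a range from 28% to 56%.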

Compound 4, a percentage reported as activity, at one concentration (the size of the read-out at that concentration, not a potency): 43.6%
Compound 4: the middle estimate sits 1.6 percentage points below what was measured, and the stated range covers the measured number.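

In this assay, going from hydroxy to methoxy gives a number 11.5 percentage points higher from compound 3 to compound 4 (beyond the scatter). Set beside the step on the core of compound 1, the change carries over between the two cores with no difference in size that stands out from the scatter: the same change on two cores in this assay, a number 10.9 percentage points higher (beyond the scatter) from compound 1 to compound 2 and a number 11.5 percentage points higher (beyond the scatter) from compound 3 to compound 4, 0.6 percentage points apart, within the scatter of two such steps. This rests on two pairs in one assay, so it does not show that the step would hold on any other core, and it does not explain the rise in the number.

The compounds shown leave open whether an ethyl group or a longer chain on that oxygen would give a step of similar size. They also leave open what an amine in place of the hydroxy group would give.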